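Configuration change from compound 2 to compound 4

The source may hold more compounds than are shown below. What is called first, only, known or untested is meant among the compounds shown, and "the series" means these compounds.

In a functional assay on HeLa cells (Homo sapiens) for cytotoxicity, read by MTT assay, with a stated time of 96 h (on this read-out higher numbers stand for weaker inhibition and lower numbers for stronger inhibition), compound 2 `CC(=O)N[C@@H](CCCN)CC(=O)N[C@@H]1[C@H](O)[C@@H](O)[C@@H](COC(N)=O)O[C@H]1/N=C1\N[C@@H]2[C@H](O)CNC(=O)[C@H]2N1` gives > 10000 nM as a limit and not a number. Compound 1 `CC(=O)N[C@@H](CCCN)CC(=O)N[C@@H]1[C@H](O)[C@@H](O)[C@@H](COC(N)=O)O[C@@H]1/N=C1\N[C@@H]2[C@H](O)CNC(=O)[C@H]2N1` gives > 10000 nM as a limit as well. Compound 3 `CC(=O)N[C@@H](CCCN)CC(=O)N[C@@H]1[C@H](O)[C@@H](O)[C@@H](COC(N)=O)O[C@H]1/N=C1\N[C@H]([C@H](O)CN)[C@@H](C(=O)O)N1` gives > 10000 nM as a limit too. Compound 2 therefore has no numerical position in the series, and no compound shown can be placed ahead of another.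

Compound 4 `CC(=O)N[C@@H](CCCN)CC(=O)N[C@@H]1[C@H](O)[C@@H](O)[C@@H](COC(N)=O)O[C@H]1/N=C1\N[C@@H]2[C@H](O)CNC(=O)[C@@H]2N1` is the next case, with the change the two compounds have the same atoms and bonds and differ only in configuration as drawn: 1 of 10 stereo elements differ; a stereocentre at a saturated ring carbon is drawn S in compound 2 and R in compound 4 and no atom or bond gained or lost. For the measured compounds named here, the one measured step that bears on this is a step that the two limits leave unreadable from compound 1 to compound 2 and it is relevant through the fact that compounds 1 and 2 differ only in the configuration as drawn as the only other change of this kind. Going by these compounds, its size stays unknown because of the limit of > 10000 nM in this assay, at which 3 of the 3 values shown sit, and it offers no magnitude to carry over. On this evidence, no step beyond the scatter is expected in this assay and no direction is assigned. The estimated step is a step that the limit leaves unreadable from compound 2 to compound 4 and it remains an expectation measured against a limit, not against a number. For compound 4 the expected value is 15000 nM with an estimated range of 10000 nM to 40000 nM and a report as a limit is the likeliest outcome.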

Compound 4, half-maximal inhibitory concentration: > 10000 nM
Compound 4: no number, only a limit (the forecaster's own chance of this, stated with the estimate: 90%); the middle value is on the limit's open side.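

In this assay compound 4 gives > 10000 nM, which is a limit and not a number. The steps to compound 4 from compound 1 and compound 2 therefore cannot be read. The compounds shown leave open whether any of these configuration changes shifts the read-out at all, and in which direction, with every value resting on one limit: the limit of > 10000 nM in this assay, at which 4 of the 4 values shown sit.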